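Triazole side chain variation on the shared core

This account rests on a few compounds, and the source may have more. Where it says the series, first, only, none or still open, it means among the compounds named here.

compound 1 `O=c1cc(Cn2cc(CCCCl)nn2)c2ccc(O)cc2o1`: > 100000 nM
compound 2 `O=c1cc(Cn2cc(CCO)nn2)c2ccc(O)cc2o1`: > 100000 nM
compound 3 `CC(O)c1cn(Cc2cc(=O)oc3cc(O)ccc23)nn1`: > 100000 nM

All three values in a functional assay on HepG2 cells (Homo sapiens) for inhibition, read by MTT assay, with a stated time of 72 h (on this read-out higher numbers stand for weaker inhibition and lower numbers for stronger inhibition), are limits, not numbers. Compound 1 sits at a limit, > 100000 nM. Compound 2 likewise sits at a limit, > 100000 nM. Compound 3 sits at a limit too, > 100000 nM, so it cannot be ordered against the other two; the limit of > 100000 nM in this assay, at which 3 of the 3 values shown sit, is all that is known. The steps a step that the two limits leave unreadable from compound 1 to compound 2, a step that the two limits leave unreadable from compound 1 to compound 3 and a step that the two limits leave unreadable from compound 2 to compound 3 are therefore unreadable in size and direction. Compound 4 `O=c1cc(Cn2cc(CCCO)nn2)c2ccc(O)cc2o1` differs from compound 3 by 3-hydroxypropyl in place of 1-hydroxyethyl on an aromatic carbon. Among the compounds with values here, no measured step bears readably on this change, and with every value at the limit no step beyond the scatter is expected in this assay. Compound 4 is expected at about 150000 nM, between 60000 nM and 400000 nM, most likely reported again only as a limit. The step that the limit leaves unreadable from compound 3 to compound 4 is expected to be none beyond the scatter.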

Compound 4, half-maximal inhibitory concentration: > 100000 nM
Compound 4: no number, only a limit; the forecaster's own chance of this, stated with the estimate: 80%; the middle value is on the limit's open side.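

Within the data shown here, compound 4 gives > 100000 nM in this assay, a limit and not a number, so no step from compound 1, compound 2 or compound 3 to compound 4 can be read. The compounds shown leave open whether any of these side chains on the shared core differs from another, since all stand at one limit: the limit of > 100000 nM in this assay, at which 4 of the 4 values shown sit.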